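Ester change on the pyridin-4-yl compound

The source may report more compounds than this note shows. Statements on the series, on what has been measured and on what is new or still open speak of the compounds shown alone.

Compound 1 `CC1=NC(C)=C([N+](=O)[O-])C(c2ccncc2)/C1=C(\O)OC(C)(C)C` gives 2820 nM in a functional assay (cardiac atrium) for agonist activity, with Cavia porcellus as the target (on this read-out lower numbers stand for an effect already at smaller amounts and higher numbers for an effect only at larger amounts of compound), the lowest of the two numbers recorded; compound 2 `CC1=NC(C)=C([N+](=O)[O-])C(c2ccccn2)/C1=C(\O)OC(C)(C)C` gives 1810000 nM, and the step of a 640-fold higher number from compound 1 to compound 2 (2.81 log units; beyond the scatter) is the only measured one. Compound 3 `COCCO/C(O)=C1\C(C)=NC(C)=C([N+](=O)[O-])C1c1ccncc1` differs from compound 1 at the ester oxygen: 2-methoxyethyl in place of tert-butyl on an oxygen on an unsaturated carbon. Within the data shown here, the measured step concerns the pyridyl group on a saturated ring carbon, not the ester, so no recorded step bears on this change. The expected step for compound 3 is therefore small, a 1.1-fold higher number from compound 1 to compound 3 (0.03 log units; within the scatter), within or near the scatter. Compound 3 is estimated at 3000 nM, with a range from 700 nM to 13000 nM.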

Compound 3, half-maximal effective concentration: 37700 nM
Compound 3: middle estimate off by 13-fold (1.10 log units), on the low side; the measured number lies above the stated range.
By their numbers in this assay, from the lowest: compound 1; then compound 3; then compound 2.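

The ester oxygen is not a silent place in the series: in this assay 2-methoxyethyl in place of tert-butyl gives a 13-fold higher number from compound 1 to compound 3 (1.13 log units; beyond the scatter) and the exchange keeps the heavy-atom count at 4. With pyridin-4-yl held constant, the tert-butyl ester therefore has the lower number of the pair. Nothing measured here accounts for this step. Still open, on these data alone, is whether the same ester change gives a step of this size with pyridin-2-yl in place of pyridin-4-yl. Also open, as far as these compounds go, is how a methyl ester, or an ester chain ending in an amine, would compare with these two.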